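Hydroxy to methoxy in a cell assay

This account rests on a few compounds, and the source may have more. Where it says the series, first, only, none or still open, it means among the compounds named here.

Compound 1 `CCCNNC(=O)c1ccc(CNC(=O)c2cc3cc(O)ccc3o2)cc1` gives 40 nM
Compound 2 `CCCNNC(=O)c1ccc(CNC(=O)c2cc3cc(OC)ccc3[nH]2)cc1` gives 37.5 nM

Both compounds were tested in a functional assay on MV4-11 cells (Homo sapiens) for antiproliferative activity, with a stated time of 48 h (a lower number here means a stronger inhibitor, a higher number a weaker inhibitor), and their two numbers lie within the usual scatter of each other, so compound 1 stands level with compound 2. Compound 3 `CCCNNC(=O)c1ccc(CNC(=O)c2cc3cc(OC)ccc3o2)cc1` changes compound 1 in one place, methyl in place of hydrogen on an oxygen on an aromatic ring with methyl in place of hydrogen on an oxygen on an aromatic ring, which reads as hydroxy to methoxy. Compound 2 also carries a methoxy group and gives 37.5 nM so no change beyond the scatter is expected, and no clear direction. The expected size is a 1.1-fold lower number from compound 1 to compound 3 (0.02 log units; within the scatter) as a rough guess. The estimate for compound 3 is 38 nM with 13 nM to 110 nM as its likely range.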

Compound 3, half-maximal inhibitory concentration: 52.1 nM
Estimate against measurement, compound 3: 1.4-fold (0.14 log units) below; low and high end bracket the measured number.
By their numbers in this assay, from the lowest: compounds 2, 1 and 3 (each within the scatter of the next).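

Replacing hydroxy with methoxy on this aromatic ring, in this assay, gives a small step (a 1.3-fold higher number from compound 1 to compound 3 (0.11 log units; within the scatter)). Adding a methyl on this oxygen therefore does not shift the reading beyond the scatter, and the hydrogen it replaces is not needed for a number of this size in these cells. Nothing available explains why the two compounds read alike.

Still open, from the compounds shown here alone, is whether a longer chain on this oxygen, such as ethoxy or benzyloxy, would also leave the number level. An amine in place of the hydroxy is a further open case.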